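This account rests on a few compounds, and the source may have more. Where it says the series, first, only, none or still open, it means among the compounds named here.

Compound 1 `CCCCCCC[C@H]1C[C@H](Cl)CCN1S(=O)(=O)c1ccc(C)cc1` and compound 3 `CCCCCCC[C@H]1C[C@H](Br)CCN1S(=O)(=O)c1ccc(C)cc1` share one core, the two differing by bromo in place of chloro on a saturated ring carbon. In a functional assay on SW1573 cells (Homo sapiens) for antiproliferative activity, read by sulforhodamine B assay, with a stated time of 48 h (a lower number here means a stronger inhibitor of growth, a higher number a weaker inhibitor of growth), compound 1 reaches only the limit > 100000 nM. Compound 3 likewise reaches only the limit > 100000 nM in this assay. This leaves a step that the two limits leave unreadable from compound 1 to compound 3, as both sit at the limit of > 100000 nM in this assay, at which 2 of the 3 values shown sit. Compound 2 `Cc1ccc(S(=O)(=O)N2CC[C@@H](Cl)C[C@@H]2C2CCCCC2)cc1` differs from compound 1 by cyclohexyl in place of heptyl on a saturated ring carbon, and in this assay compound 2 gives 53000 nM, a step of an at least 1.8-fold lower number from compound 1 to compound 2 (0.27 log units; that floor lies within the scatter). Compound 4 `Cc1ccc(S(=O)(=O)N2CC[C@@H](Br)C[C@@H]2C2CCCCC2)cc1` differs from compound 3 by cyclohexyl in place of heptyl on a saturated ring carbon, the same kind of change, the surroundings differing only in that the ring atom two ring bonds from the place bears a bromo group rather than a chloro group. Resting on an at least 1.8-fold lower number from compound 1 to compound 2 (0.27 log units; that floor lies within the scatter), the step from compound 3 to compound 4 is expected to be an at least 1.6-fold lower number from compound 3 to compound 4 (0.22 log units; that floor lies within the scatter). Compound 4 is therefore estimated at 60000 nM in this assay, between 25000 nM and 150000 nM.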

Compound 4, concentration for 50% growth inhibition: 82000 nM
Estimate against measurement, compound 4: 1.4-fold (0.14 log units) below, and the stated range covers the measured number.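

In this assay, cyclohexyl in place of heptyl gives an at least 1.2-fold lower number from compound 3 to compound 4 (0.08 log units; that floor lies within the scatter), and set beside the same change on the chloro core the result is: the same change on two cores in this assay, an at least 1.8-fold lower number (0.27 log units; that floor lies within the scatter) from compound 1 to compound 2 and an at least 1.2-fold lower number (0.08 log units; that floor lies within the scatter) from compound 3 to compound 4; the limit leaves it open whether they differ. This shows nothing that separates the two cores, but it does not show that the change carries over with the same size, or that it lowers the number beyond the scatter on either core, as both heptyl compounds stand at a limit. On the cyclohexyl core, bromo in place of chloro gives a 1.5-fold higher number from compound 2 to compound 4 (0.19 log units; within the scatter), so that swap leaves the comparison of the two cores undisturbed.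

On these data alone, whether a phenyl ring or a shorter chain in place of cyclohexyl would lower the number beyond the scatter stays open. So does the effect of an amine or a hydroxyl in place of the bromo group.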